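The source may report more compounds than this note shows. Statements on the series, on what has been measured and on what is new or still open speak of the compounds shown alone.

Working notes on the series. Compound 1 `ClCc1ccc(Cn2cnc3c(Cl)ncnc32)cc1` is the point of departure; in a functional assay on HCT-116 cells (Homo sapiens) for cytotoxicity, read by sulforhodamine B assay, with a stated time of 48 h (a higher number here means that more compound is tolerated, a lower number that less compound is tolerated), compound 1 gives 25100 nM, the highest of the two numbers in hand. The nearest numbered neighbour is compound 2 `ClCc1ccccc1Cn1cnc2c(Cl)nc(Cl)nc21`, which in this assay gives 750 nM, a gap that is beyond the scatter. Compound 3 `ClCc1ccc(Cn2cnc3nc(Cl)nc(Cl)c32)cc1` belongs to the same set. For compound 3 this assay reports only a limit of > 100000 nM, not a number; this sits at the limit of > 100000 nM in this assay, at which 1 of the 3 values shown sits. Going by the values given here, compound 3 and compound 2 differ from compound 1 in more than one place, so no single step between measured compounds is available.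

The not yet measured compound 4 `ClCc1ccc(Cn2cnc3c(Cl)nc(Cl)nc32)cc1` differs from compound 1 by chloro in place of hydrogen on an aromatic carbon. Among the compounds with values here, with no matched pair in hand, the direction of the step is open; compound 2 carries the second chloro and gives 750 nM. Compound 3 also carries the second chloro, and for compound 3 only a limit, not a number, is in hand. The expected step in this assay from compound 1 to compound 4 is a 3.1-fold lower number from compound 1 to compound 4 (0.50 log units; beyond the scatter), a downward shift beyond the scatter. For compound 4 the estimate in this assay is 8000 nM, expected to fall between 1500 nM and 60000 nM.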

Compound 4, concentration lethal to 50% of the cells: 7590 nM
Compound 4: middle estimate off by 1.1-fold (0.02 log units), on the high side, within the range that was stated.
By their numbers in this assay, from the lowest: compound 2; then compound 4; then compound 1. At a limit, above all of these: compound 3.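

In this assay, the series now has its first matched pair. Chloro in place of hydrogen on an aromatic carbon, at the position between two ring nitrogen atoms, gives a 3.3-fold lower number from compound 1 to compound 4 (0.52 log units; beyond the scatter), so this single change on the shared core has a direction and a size that lie beyond the scatter, which compound 2 and compound 3 could not show because each differs from compound 1 in more than one place. Nothing in hand bears on why the number moves.

On these data alone, whether another group at this position, such as an amine or a methoxy group, would move the number in the same direction remains open. As far as these compounds go, whether the same chloro step holds in the settings of compound 2 and compound 3 also remains open.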